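A second fluorine on an inactive aryl ketone

A few compounds are considered here, and "the series" means these few. Any claim that something is new, unique, unknown or untested is made for them only; others in the source may bear on it.

Three compounds share one core and differ only in the group on the sulfur-bound chain carbon. Compound 1 `C=CCSc1nnc(-c2cc(OC)c(OC)c(OC)c2)n1N1C(=O)c2ccccc2C1=O` carries a vinyl there, compound 2 `COc1cc(-c2nnc(SCC(=O)c3ccc(C)cc3)n2N2C(=O)c3ccccc3C2=O)cc(OC)c1OC` a (4-methylphenyl)carbonyl, and compound 3 `COc1cc(-c2nnc(SCC(=O)c3ccc(F)cc3)n2N2C(=O)c3ccccc3C2=O)cc(OC)c1OC` a (4-fluorophenyl)carbonyl. In a functional assay on A549 cells (Homo sapiens) for cytotoxicity, read by MTT assay, with a stated time of 48 h (a higher number here means a weaker inhibitor, a lower number a stronger inhibitor), compound 2 gives 6760 nM. For compound 1 the result is a limit of the assay, > 200000 nM. For compound 3 the result is likewise only a limit, > 200000 nM. The step of an at least 29-fold lower number from compound 1 to compound 2 (1.47 log units; beyond the scatter) is large, whereas a step that the two limits leave unreadable from compound 1 to compound 3 cannot be sized. Most telling is an at least 29-fold higher number from compound 2 to compound 3 (1.47 log units; beyond the scatter), a large loss, which brings compound 3 onto (the limit of > 200000 nM in this assay, at which 2 of the 3 values shown sit). Compound 3 thus stands at the weak edge of the numbers shown, with compound 2 the only one giving a true number.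

Compound 4 `COc1cc(-c2nnc(SCC(=O)c3ccc(F)c(F)c3)n2N2C(=O)c3ccccc3C2=O)cc(OC)c1OC` differs from compound 3 by fluoro in place of hydrogen on an aromatic carbon. Within the data shown here, no measured step shows fluoro in place of hydrogen, so the nearest guide is the limit of compound 3 itself. The expected step of a number no higher from compound 3 to compound 4 (the limit leaves the size open) is therefore none beyond the scatter. Compound 4 is estimated at 200000 nM, with a range from 40000 nM to 600000 nM.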

Compound 4, half-maximal inhibitory concentration: > 200000 nM
Compound 4: a limit, no number (the forecaster's own chance of this, stated with the estimate: 70%); the middle value lies on the limit itself.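

A second fluoro, ortho to the first and meta to the large group, brings no readable number back in this assay, so adding to the fluorinated ring of compound 3 at this position does not recover what the ring of compound 2 gives: the limit of > 200000 nM in this assay, at which 3 of the 4 values shown sit.

The loss relative to the 4-methylphenyl ketone now holds for a second fluorinated ring, with an at least 29-fold higher number from compound 2 to compound 4 (1.47 log units; beyond the scatter). The steps from compound 3 to compound 4 and from compound 1 to compound 4 cannot be read, as both ends of each are limits.

The aryl ketones shown carry only methyl or fluoro on the ring. A chloro, a methoxy or an amine there, or a plain phenyl ketone, would help show whether the methyl of compound 2 is what gives a true number or whether fluoro is what takes it away.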